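From 2,4-dichlorobenzyl to 4-chlorobenzyl in compound 2

The source may hold more compounds than are shown below. What is called first, only, known or untested is meant among the compounds shown, and "the series" means these compounds.

Compound 1 `Cc1cc(C)cc(/C=C(\C(=O)c2ccc(Cl)cc2)S(=O)(=O)Cc2ccc(Cl)cc2)c1`: 1000 nM
Compound 2 `Cc1ccc(/C=C(\C(=O)c2ccc(Cl)cc2)S(=O)(=O)Cc2ccc(Cl)cc2Cl)s1`: 10000 nM

In a functional assay on DU-145 cells (Homo sapiens) for inhibition, read by trypan blue exclusion, with a stated time of 96 h (on this read-out lower numbers stand for stronger inhibition of growth and higher numbers for weaker inhibition of growth), compound 2 holds the higher of the two numbers at 10000 nM, beyond the scatter from the other compound. Compound 3 `Cc1ccc(/C=C(\C(=O)c2ccc(Cl)cc2)S(=O)(=O)Cc2ccc(Cl)cc2)s1` differs from compound 2 in one place: hydrogen in place of chloro on an aromatic carbon, with hydrogen in place of chloro on an aromatic carbon, turning 2,4-dichlorobenzyl into 4-chlorobenzyl. Among the compounds with values here, no measured pair shows this change alone. The 4-chlorobenzyl group also occurs in compound 1 at 1000 nM, though that compound differs elsewhere too. A moderate move towards a lower number in this assay is therefore expected, with an estimated 3.3-fold lower number from compound 2 to compound 3 (0.52 log units; beyond the scatter). The expected value for compound 3 is 3000 nM, within a range of 800 nM to 10000 nM.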

Compound 3, concentration for 50% growth inhibition: 1000 nM
Compound 3: middle estimate off by 3.0-fold (0.48 log units), on the high side; the measured number falls inside the stated range.
By their numbers in this assay, from the lowest: compounds 1 and 3 (each within the scatter of the next); then compound 2.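

In this assay, within the data shown here, the single change of hydrogen in place of chloro on this aromatic carbon gives a 10-fold lower number from compound 2 to compound 3 (1.00 log units; beyond the scatter) as a clean one-place comparison, so the chloro of 2,4-dichlorobenzyl counts against growth inhibition. With 4-chlorobenzyl in place, the aryl group can be exchanged, as no change at the digits printed from compound 1 to compound 3 (within the scatter) shows for 5-methylthiophen-2-yl in place of 3,5-dimethylphenyl. No supporting data explain either result.

From the compounds shown here alone, whether a fluoro, methyl or methoxy group on this aromatic carbon would behave like chloro or like hydrogen stays open. So does whether the same step holds with 3,5-dimethylphenyl as the aryl group.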